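Methyl-to-hydrogen step carried from one core to another

This account rests on a few compounds, and the source may have more. Where it says the series, first, only, none or still open, it means among the compounds named here.

Compound 1 `Cc1ccnc(/C(N)=N/NC(=S)N2CCN(c3ccccn3)CC2)c1` and compound 2 `Cc1ccnc(/C(N)=N/NC(=S)N2CCSCC2)c1` carry different cores; the difference between the two cores is not broken down here. In a functional assay on HeLa cells (Homo sapiens) for cytotoxicity, read by MTT assay, with a stated time of 72 h, tested at 30 uM (a higher number here means more inhibition of growth at the concentration tested, a lower number less inhibition of growth), compound 1 gives 77% and compound 2 gives 78.3%. Compound 3 `N/C(=N\NC(=S)N1CCSCC1)c1ccccn1` differs from compound 2 by hydrogen in place of methyl on an aromatic carbon, and in this assay compound 3 gives 80.6%; the step of a number 2.3 percentage points higher from compound 2 to compound 3 (within the scatter). Compound 4 `N/C(=N\NC(=S)N1CCN(c2ccccn2)CC1)c1ccccn1` has not been measured and differs from compound 1 by hydrogen in place of methyl on an aromatic carbon, the same change at the same place on the other core. Because the step of a number 2.3 percentage points higher from compound 2 to compound 3 (within the scatter) was within the scatter, in this assay the expected step is a number 2 percentage points higher from compound 1 to compound 4 (within the scatter). Compound 4 is estimated at 79%, expected to lie between 69% and 88%.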

Compound 4, percent growth inhibition at one concentration: 78.9%
The estimate for compound 4 lay 0.1 percentage points above the measured number, within the range that was stated.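

In this assay, the exchange of 4-methylpyridin-2-yl for pyridin-2-yl on the core of compound 1 gives a step that is a number 1.9 percentage points higher from compound 1 to compound 4 (within the scatter). The change reads alike on both cores: the same change on two cores in this assay, a number 2.3 percentage points higher (within the scatter) from compound 2 to compound 3 and a number 1.9 percentage points higher (within the scatter) from compound 1 to compound 4, 0.4 percentage points apart, within the scatter of two such steps. For the compounds shown here, this shows agreement between two steps that each stay within the scatter, not a methyl effect of a definite size that carries over, and with only two cores at one tested concentration it supports no general rule for the series.

The compounds shown leave open whether a different group at the same place, such as an amine, a carboxylic acid or a longer chain, would give a step beyond the scatter. They also leave open whether any such step would carry between these two cores.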